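A Methyl Added on the Chain Carbon of Compound 3

The compounds below may be only part of what the source reports. "The series", "measured", "known", "first", "only" and "open" are said of these compounds alone.

For the measured compounds named here, compound 3 `CC(C)(C(=O)NCc1ccc(C(F)(F)F)nc1SC1CCCCC1)c1ccc(NS(C)(=O)=O)c(F)c1` is one of three compounds measured in an assay on CHO cells for antagonist activity at transient receptor potential cation channel subfamily V member 1 (Homo sapiens), read by FLIPR; on this read-out higher numbers stand for weaker inhibition and lower numbers for stronger inhibition. Compound 1 `Cc1ccccc1C(C(=O)NCc1ccc(C(F)(F)F)nc1N1CCC(C)CC1)c1ccc(NS(C)(=O)=O)c(F)c1` gives 42.9 nM, compound 2 `CC1CCN(c2nc(C(F)(F)F)ccc2CNC(=O)C(C)(C)c2ccc(NS(C)(=O)=O)c(F)c2)CC1` gives 49 nM, and compound 3 gives 65.7 nM; compound 3 thus carries the highest of the three numbers, though its gaps to both others lie within the scatter. Going by the values given here, the only measured step, a 1.3-fold higher number from compound 2 to compound 3 (0.13 log units; within the scatter), concerns a different part of the molecule. Compound 4 `CCC(C)(C(=O)NCc1ccc(C(F)(F)F)nc1SC1CCCCC1)c1ccc(NS(C)(=O)=O)c(F)c1` differs from compound 3 by methyl in place of hydrogen on a saturated chain carbon, two bonds along the chain from an aromatic carbon and a carbonyl carbon. Among the compounds with values here, no measured step touches this chain carbon, so nothing supports a move beyond the scatter in this assay; the step of a 1.1-fold higher number from compound 3 to compound 4 (0.03 log units; within the scatter) is the estimate. Compound 4 is therefore expected to give about 70 nM, with a range from 30 nM to 160 nM.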

Compound 4, inhibition constant: "active" (no number reported)
For compound 4 the study gives words and no number, and the estimate cannot be compared.
By their numbers in this assay, from the lowest: compounds 1, 2 and 3 (each within the scatter of the next).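

For the compounds shown here, compound 4 is reported only as active, without a number, so no step from compound 3 to compound 4 can be read. Whether methyl in place of hydrogen on this chain carbon changes the number stays open, and no evidence shown here bears on the result.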